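A few compounds are considered here, and "the series" means these few. Any claim that something is new, unique, unknown or untested is made for them only; others in the source may bear on it.

Measured so far in an assay on HT-29 cells with Methylated-DNA--protein-cysteine methyltransferase (Homo sapiens) as the target, with a stated time of 4 h; on this read-out higher numbers stand for an effect only at larger amounts of compound and lower numbers for an effect already at smaller amounts:
compound 1 `Nc1nc(OCc2ccccc2)c2[nH]c(Br)nc2n1` gives 0.06 uM;
compound 2 `Oc1nc(OCc2ccccc2)c2[nH]cnc2n1` gives 35 uM;
compound 3 `Oc1nc(OCc2ccccc2)c2[nH]c(O)nc2n1` gives 45 uM.

Compound 2 stands second highest of the three numbers in this assay; its nearest neighbour is compound 3, the step of a 1.3-fold higher number from compound 2 to compound 3 (0.11 log units; within the scatter) lying within the scatter, while compound 1 lies far below it, the gap being beyond the scatter. Compound 1 differs from compound 2 in two places at once, so only its value can be set beside that of compound 2, and no single step can be read off.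

Compound 4 `Fc1nc(OCc2ccccc2)c2[nH]cnc2n1` is not yet measured. Its change from compound 2 is fluoro in place of hydroxy on an aromatic carbon. Going by the values given here, no measured step touches this exact exchange. Among the compounds with values here, the one step available, a 1.3-fold higher number from compound 2 to compound 3 (0.11 log units; within the scatter), concerns a hydroxy entering elsewhere on the shared core and left the number unchanged within the scatter. The values of compound 1 and compound 2 show that what sits on this carbon can shift the number strongly, but with two changes in that pair no share can be assigned to the hydroxy alone.

The expectation for compound 4 is therefore a lower number than compound 2 by a moderate step, a 4.4-fold lower number from compound 2 to compound 4 (0.64 log units; beyond the scatter), with wide uncertainty. The estimate for compound 4 in this assay is 8 uM, within a range from 1.5 uM to 40 uM.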

Compound 4, concentration for half-maximal effect: 12 uM
Estimate against measurement, compound 4: 1.5-fold (0.18 log units) below; the range from low to high includes it.
By their numbers in this assay, from the lowest: compound 1; then compound 4; then compounds 2 and 3 (each within the scatter of the next).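

In this assay, going by these compounds alone, the exchange of hydroxy for fluoro gives the first single-place reading at this aromatic carbon between two ring nitrogen atoms: a 2.9-fold lower number from compound 2 to compound 4 (0.46 log units; beyond the scatter). Within the data shown here, the earlier compounds showed only that the number can differ widely across the series, whereas this step shows that this exchange alone moves it beyond the scatter, though only modestly, with the hydrogen-bond donor and acceptor counted for hydroxy absent from fluoro. No measurement shown here bears on the reason for this shift.

Compound 1 differs from compound 4 in two places: it carries an amine on this carbon and a bromo where compound 3 carries its second hydroxy. Among these compounds, the compounds measured so far do not separate these two changes. An amine on this carbon with hydrogen kept at that second place would separate the two, and a bromo at that second place with fluoro kept here would test the other half, while a chloro or methoxy group here would show whether fluoro's step extends to other replacements for hydroxy.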